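A Larger Ester Side Chain Replaces a Small Ether

A few compounds are considered here, and "the series" means these few. Any claim that something is new, unique, unknown or untested is made for them only; others in the source may bear on it.

Measured compounds:
compound 1 `CC(C)=CC[C@@H](OC[C@@H](C)O)C1=CC(=O)c2c(O)ccc(O)c2C1=O` — 14300 nM
compound 2 `CC(C)=CC[C@@H](OCC(C)O)C1=CC(=O)c2c(O)ccc(O)c2C1=O` — 16100 nM

Both compounds share the same core and differ only in the side chain attached through an oxygen. In a functional assay on DU-145 cells (Homo sapiens) for cytotoxicity, read by MTT assay (on this read-out higher numbers stand for weaker inhibition and lower numbers for stronger inhibition), compound 1 gives the lowest of the two numbers, yet the step of a 1.1-fold higher number from compound 1 to compound 2 (0.05 log units; within the scatter) is small, which fits (the fact that one of compounds 1 and 2 is drawn with a defined configuration and the other without, at the place where they differ).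

Compound 3 `CCCCC(C)(O)CC(=O)O[C@H](CC=C(C)C)C1=CC(=O)c2c(O)ccc(O)c2C1=O` is not yet measured. It differs from compound 1 in one place: (2-hydroxy-2-methylhexyl)carbonyl in place of 2-hydroxypropyl on an oxygen on a saturated carbon. The group that enters is much larger than the one that leaves and carries an extra double bond outside aromatic rings and an extra hydrogen-bond acceptor.

Within the data shown here, the only measured step concerns a drawn configuration, not a change of atoms, so it says nothing about swapping a 2-hydroxypropyl group for a (2-hydroxy-2-methylhexyl)carbonyl group. Without a comparable step, the expected change in this assay is none beyond the scatter, though the wide range reflects the size of the alteration. Compound 3 is therefore estimated at 11000 nM, between 3000 nM and 40000 nM, an expected step of a 1.3-fold lower number from compound 1 to compound 3 (0.11 log units; within the scatter).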

Compound 3, half-maximal inhibitory concentration: 76500 nM
Beside the measured number, compound 3's estimate is 7.0-fold (0.84 log units) below it; measured number above the stated range.
By their numbers in this assay, from the lowest: compounds 1 and 2 (each within the scatter of the next); then compound 3.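

Until this point, the only difference at this oxygen on a saturated carbon was a drawn configuration within the 2-hydroxypropyl group, and that left the numbers within the scatter. Among these compounds, replacing the whole group with (2-hydroxy-2-methylhexyl)carbonyl is the first change of atoms here, and in this assay it gives a 5.3-fold higher number from compound 1 to compound 3 (0.73 log units; beyond the scatter) and a 4.8-fold higher number from compound 2 to compound 3 (0.68 log units; beyond the scatter), so what sits on this oxygen does affect the read-out, and compound 3 is the weakest of the set, though both steps are modest. Among the compounds shown here, the only information at hand concerns a drawn configuration and offers no cause for this rise.

The swap changes two things at once, adding a carbonyl on the oxygen and lengthening the chain, and the compounds shown do not separate these two changes. An acetyl group on the same oxygen would carry the carbonyl without the long chain, a 2-hydroxyhexyl group would carry a long chain without the carbonyl, and either could show which change goes with the higher number.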